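The source may report more compounds than this note shows. Statements on the series, on what has been measured and on what is new or still open speak of the compounds shown alone.

Working notes on the group carried on the oxygen of the shared core. In a functional assay on HeLa cells (Homo sapiens) for antiproliferative activity, read by MTT assay, with a stated time of 48 h (on this read-out higher numbers stand for weaker inhibition and lower numbers for stronger inhibition), compound 3 (`COc1cc(-c2nnc3c(OCC(F)(F)F)cc(-c4ccc5c(ccn5C)c4)cn23)cc(OC)c1OC`) gives 199 nM, and compound 1 (`CCOc1cc(-c2ccc3c(ccn3C)c2)cn2c(-c3cc(OC)c(OC)c(OC)c3)nnc12`) gives 210 nM. These two cannot be told apart: a 1.1-fold lower number from compound 1 to compound 3 (0.02 log units; within the scatter). Compound 2 (`COc1cc(-c2nnc3c(OC(C)C)cc(-c4ccc5c(ccn5C)c4)cn23)cc(OC)c1OC`) stands apart at 503 nM, the highest number of the three.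

The next compound is compound 4 (`COc1cc(-c2nnc3c(OC4CCC4)cc(-c4ccc5c(ccn5C)c4)cn23)cc(OC)c1OC`), with this change from compound 3: cyclobutyl in place of 2,2,2-trifluoroethyl on an oxygen on an aromatic ring. In words, cyclobutyl comes in place of 2,2,2-trifluoroethyl on an oxygen on an aromatic ring.

All three measured steps are changes at this same oxygen. Two are modest but beyond the scatter: a 2.4-fold higher number from compound 1 to compound 2 (0.38 log units; beyond the scatter) and a 2.5-fold lower number from compound 2 to compound 3 (0.40 log units; beyond the scatter). Going by the values given here, both involve the isopropyl group of compound 2, the only measured group branched at the carbon on the oxygen. Cyclobutyl shares that branching, so compound 2 is the closest guide, although no ring-bearing group has been measured and three compounds make a thin basis.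

A modest move towards a higher number, meaning weaker inhibition, is expected: a 2.1-fold higher number from compound 3 to compound 4 (0.32 log units; beyond the scatter). Compound 4 is estimated at 420 nM, with an expected range of 200 nM to 850 nM.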

Compound 4, half-maximal inhibitory concentration: 177 nM
For compound 4 the middle estimate is 2.4-fold (0.38 log units) above the measured one; the measured number lies below the stated range.
By their numbers in this assay, from the lowest: compounds 4, 3 and 1 (each within the scatter of the next); then compound 2.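

In this assay branching at the carbon on the oxygen does not by itself go with a higher number: the change from isopropyl to cyclobutyl gives a 2.8-fold lower number from compound 2 to compound 4 (0.45 log units; beyond the scatter) even though both groups share that branching. Cyclobutyl also cannot be told apart from the two unbranched groups, with a 1.1-fold lower number from compound 3 to compound 4 (0.05 log units; within the scatter) and a 1.2-fold lower number from compound 1 to compound 4 (0.07 log units; within the scatter) as the steps, so a four-membered ring of carbon only, 2,2,2-trifluoroethyl and ethyl all read alike here, and compound 2, with isopropyl, is now the only one of the four set apart, as the weakest. No supporting data are available to explain why isopropyl differs from cyclobutyl at this oxygen.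

Still open, as far as these compounds go, is whether the flat reading extends to larger rings such as cyclopentyl or cyclohexyl, to a more heavily branched tert-butyl group, or to a longer chain such as n-butyl. Also open, from the compounds shown here alone, is how this oxygen tolerates a chain ending in an amine or a carboxylic acid, or a free hydroxyl in place of the ether.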